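Aryl replacement on the anilino nitrogen of the purine series

The source may report more compounds than this note shows. Statements on the series, on what has been measured and on what is new or still open speak of the compounds shown alone.

In a functional assay on EOL1 cells (Homo sapiens) for inhibition, read by fluorescence, with a stated time of 72 h (on this read-out higher numbers stand for weaker inhibition of growth and lower numbers for stronger inhibition of growth), compound 1 `CCCCCCn1cnc2c(Nc3cccc(Cl)c3)nc(N[C@H]3CC[C@H](N)CC3)nc21` gives 310 nM. Compound 2 `CCCCn1cnc2c(Nc3cccc(Cl)c3)nc(N[C@H]3CC[C@H](N)CC3)nc21` gives 160 nM in this assay, the lowest of the two numbers shown, though the step of a 1.9-fold lower number from compound 1 to compound 2 (0.29 log units; within the scatter) is within the scatter, so the two cannot be ordered. That step concerns the chain on the ring nitrogen only and says nothing about the aryl group on the other nitrogen.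

Compound 3 `CCCCn1cnc2c(Nc3cc(OC)cc(OC)c3)nc(N[C@H]3CC[C@H](N)CC3)nc21` keeps the chain of compound 2 and differs by 3,5-dimethoxyphenyl in place of 3-chlorophenyl on a nitrogen on an aromatic ring. Going by the values given here, no measured pair varies this aryl group, so there is no step to lean on. A change of this kind, with two acceptors entering where a chlorine leaves, could move the number in either direction; the expectation is a modest shift, most likely toward a higher number, with a wide range. Compound 3 is estimated at 400 nM (range 100 nM to 1600 nM), a step of a 2.5-fold higher number from compound 2 to compound 3 (0.40 log units; beyond the scatter) that is expected to stay near the scatter.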

Compound 3, concentration for 50% growth inhibition: 370 nM
For compound 3 the middle estimate is 1.1-fold (0.03 log units) above the measured one, within the range that was stated.
By their numbers in this assay, from the lowest: compounds 2, 1 and 3 (each within the scatter of the next, the first and the last beyond it).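

In this assay, going by these compounds alone, 3,5-dimethoxyphenyl in place of 3-chlorophenyl on a nitrogen on an aromatic ring gives a 2.3-fold higher number from compound 2 to compound 3 (0.36 log units; beyond the scatter) as the first reading on this aryl group, and the change is modest but beyond the scatter. The number therefore responds to this aryl group, whereas the chain step between compound 1 and compound 2 stayed within the scatter, and compound 3 with its methoxy groups still gives a value in the same assay range as the chlorinated pair. Nothing available here explains the direction or size of this step.

The compounds shown do not separate the loss of the chlorine from the entry of the methoxy groups, and a 3-methoxyphenyl or 3,5-dichlorophenyl group on the same nitrogen would bear on that. From the compounds shown here alone, whether the step holds with the longer chain of compound 1 also remains open.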